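Phenoxy in place of acetoxy on the arylidene ring

A few compounds are considered here, and "the series" means these few. Any claim that something is new, unique, unknown or untested is made for them only; others in the source may bear on it.

Compound 1, `CC(=O)Oc1ccc(/C=C(\C(=O)c2ccc(Cl)cc2)S(=O)(=O)c2ccc(C)cc2)cc1`, gives 25000 nM in a functional assay on DU-145 cells (Homo sapiens) for inhibition, read by trypan blue exclusion, with a stated time of 96 h; on this read-out lower numbers stand for stronger inhibition of growth and higher numbers for weaker inhibition of growth.
Compound 2, `COc1ccccc1/C=C(\C(=O)c1ccc(Cl)cc1)S(=O)(=O)c1ccc(C)cc1`, gives 1000 nM in this assay.
Compound 3, `Cc1ccc(S(=O)(=O)/C(=C/c2cccs2)C(=O)c2ccc(Cl)cc2)cc1`, gives 25000 nM in this assay.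

On these numbers compound 1 stands level with compound 3 at the digits shown, the two together forming the highest numbers of the three, while compound 2 lies far lower: a 25-fold lower number from compound 1 to compound 2 (1.40 log units; beyond the scatter). The new compound 4, `Cc1ccc(S(=O)(=O)/C(=C/c2ccc(Oc3ccccc3)cc2)C(=O)c2ccc(Cl)cc2)cc1`, differs from compound 1 only at the oxygen on the aromatic ring: phenyl in place of acetyl on an oxygen on an aromatic ring. No measured step touches that oxygen; the steps shown all exchange the whole ring on the double-bonded chain carbon. They show that a change there can be large, as in a 25-fold lower number from compound 1 to compound 2 (1.40 log units; beyond the scatter) and a 25-fold higher number from compound 2 to compound 3 (1.40 log units; beyond the scatter), or absent, as in no change at the digits printed from compound 1 to compound 3 (within the scatter). Since the ring of compound 1 is kept and only the group on its oxygen changes, a modest step is expected, leaning toward a lower number: a 2.5-fold lower number from compound 1 to compound 4 (0.40 log units; beyond the scatter). Compound 4 is therefore estimated at 10000 nM, in a range from 2000 nM to 40000 nM.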

Compound 4, concentration for 50% growth inhibition: 1000 nM
Estimate against measurement, compound 4: 10-fold (1.00 log units) above, and the stated range ends above it.
By their numbers in this assay, from the lowest: compounds 2 and 4 (each within the scatter of the next); then compounds 1 and 3 (each within the scatter of the next).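

The earlier steps shown here all exchanged the whole ring on the double-bonded chain carbon, whereas this one keeps the ring of compound 1 and alters only the group on its oxygen, and acetoxy to phenoxy alone gives a 25-fold lower number from compound 1 to compound 4 (1.40 log units; beyond the scatter) in this assay. The group on that oxygen therefore matters on its own, with a step printed at the same size as the whole-ring exchange, a 25-fold lower number from compound 1 to compound 2 (1.40 log units; beyond the scatter).

The compounds shown leave open whether the added phenyl ring or the loss of the acetyl carries this step, a question that a free hydroxyl, an ethoxy or a benzyloxy group on the same oxygen position would bear on. No measurement shown here explains why the step is so large.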